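Aryl in place of methyl on the sulfonyl sulfur

A few compounds are considered here, and "the series" means these few. Any claim that something is new, unique, unknown or untested is made for them only; others in the source may bear on it.

Going by the values given here, in a functional assay on THP-1 cells (Homo sapiens) for cytotoxicity, read by MTT assay, with a stated time of 24 h (on this read-out higher numbers stand for weaker inhibition and lower numbers for stronger inhibition), compound 1 (`COc1cc2nc(Cl)nc(NS(C)(=O)=O)c2cc1OC`) gives 99.7 ug/mL as the highest of the three numbers so far. Compound 2 (`COc1cc2nc(Cl)nc(NS(=O)(=O)c3ccc(C)cc3C)c2cc1OC`) gives 40.4 ug/mL and compound 3 (`COc1cc2nc(Cl)nc(NS(=O)(=O)c3cccc(C(F)(F)F)c3)c2cc1OC`) gives 36.4 ug/mL on the same read-out. Compound 4 (`COc1cc2nc(Cl)nc(NS(=O)(=O)c3ccc(C)cc3)c2cc1OC`) is unmeasured. Its change from compound 1 is 4-methylphenyl in place of methyl on a sulfonyl sulfur with 4-methylphenyl in place of methyl on a sulfonyl sulfur. Among the compounds with values here, the one measured step bearing on this is a 2.5-fold lower number from compound 1 to compound 2 (0.39 log units; beyond the scatter) for 2,4-dimethylphenyl in place of methyl on a sulfonyl sulfur, which is modest and beyond the scatter. A step of like size toward a lower number is therefore expected in this assay here. The estimated step is a 2.4-fold lower number from compound 1 to compound 4 (0.38 log units; beyond the scatter) as a working figure. Compound 4 is estimated at 42 ug/mL with an expected range of 24 ug/mL to 72 ug/mL for the measurement.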

Compound 4, half-maximal inhibitory concentration: 33.5 ug/mL
For compound 4 the middle estimate is 1.3-fold (0.10 log units) above the measured one; the range from low to high includes it.
By their numbers in this assay, from the lowest: compounds 4, 3 and 2 (each within the scatter of the next); then compound 1.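

A single 4-methylphenyl in place of methyl on the sulfonyl sulfur gives a 3.0-fold lower number from compound 1 to compound 4 (0.47 log units; beyond the scatter) in this assay and so the lower number does not depend on the second methyl of compound 2. Hydrogen in place of methyl on an aromatic carbon gives a 1.2-fold lower number from compound 2 to compound 4 (0.08 log units; within the scatter) and this step leaves compound 2 and compound 4 undistinguished. Nothing on hand explains either step.

Open, on these data alone, is whether an amine or a carboxylic acid on the aromatic ring would hold this level. Also open, as far as these compounds go, is how a longer chain on the sulfonyl sulfur would compare with methyl.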